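The source may hold more compounds than are shown below. What is called first, only, known or untested is meant among the compounds shown, and "the series" means these compounds.

In an ADME assay on THP-1 cells (Homo sapiens) for cytotoxicity, with a stated time of 24 h (on this read-out lower numbers stand for stronger inhibition and higher numbers for weaker inhibition), compound 2 `N#C[Se]c1ccc(NC(=O)CCC(=O)O)cc1` gives > 25000 nM, which is a limit of the assay and not a number. Compound 1 `N#C[Se]c1ccc(NC(=O)COCC(=O)O)cc1` gives > 25000 nM, and this too is a limit. The measurements so far therefore centre on (the limit of > 25000 nM in this assay, at which 2 of the 3 values shown sit). Within the data shown here, compound 3 `O=C(NC(=[Se])Nc1ccc([Se][Se]c2ccc(NC(=[Se])NC(=O)c3cc4ccccc4nc3-c3ccccc3)cc2)cc1)c1cc2ccccc2nc1-c1ccccc1`, a much larger structure, is the only one with an actual number, and in this assay compound 3 gives 8500 nM.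

The next compound to consider is compound 4 `N#C[Se]c1ccc(NC(=O)/C=C\C(=O)O)cc1`, which differs from compound 2 in one place: 2-carboxyethenyl in place of 2-carboxyethyl on a carbonyl carbon. In words, 2-carboxyethenyl replaces 2-carboxyethyl on a carbonyl carbon bound to an amide-type nitrogen, so the swapped group keeps its heavy-atom count and gains one double bond.

Among the measured compounds shown here, only one measured step involves a similar change to this part of the molecule, and it is a step that the two limits leave unreadable from compound 1 to compound 2. With limits on both sides, that step offers no size to carry over, and the other measured compound is too different to serve as a guide. No shift beyond the usual scatter is therefore expected in this assay, and no direction can be favoured. The expected result is a step that the limit leaves unreadable from compound 2 to compound 4. For compound 4, the estimated value is 30000 nM, with an expected range from 12000 nM to 70000 nM.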

Compound 4, half-maximal inhibitory concentration: > 25000 nM
Compound 4 ended at the assay's limit (the forecaster's own chance of this, stated with the estimate: 70%); the middle value is on the limit's open side.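

In this assay compound 4 gives > 25000 nM, which is a limit and not a number. The steps linking compound 1, compound 2 and compound 4 therefore cannot be read, as all three stop at the same limit: the limit of > 25000 nM in this assay, at which 3 of the 4 values shown sit.

The compounds shown leave open whether 2-carboxyethenyl in place of 2-carboxyethyl changes the result in this assay at all.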